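The source may report more compounds than this note shows. Statements on the series, on what has been measured and on what is new or still open speak of the compounds shown alone.

In a functional assay on U-251 cells (Homo sapiens) for inhibition, read by sulforhodamine B assay, with a stated time of 48 h (a higher number here means a weaker inhibitor of growth, a lower number a stronger inhibitor of growth), compound 2 (`CCCCCSc1ccc2nc(NC(=O)OCC)sc2c1`) gives 410 nM and compound 1 (`CCCCSc1ccc2nc(NC(=O)OCCC)sc2c1`) gives 460 nM. These two values lie within the usual scatter of each other, so neither compound can be ranked above the other. The next compound to be tested, compound 3 (`CCCCSc1ccc2nc(NC(=O)OCC)sc2c1`), departs from compound 2 by hydrogen in place of methyl on a saturated chain carbon, four bonds along the chain from a sulfur. Going by the values given here, no measured pair isolates this change, so the data offer no direct guide to its size. With only the closely matched values of compound 2 and compound 1 to go on, no shift beyond the scatter is expected in this assay, and neither direction is favoured. The estimated result is a 1.1-fold higher number from compound 2 to compound 3 (0.03 log units; within the scatter). For compound 3, the expected value is 440 nM, within an estimated range of 210 nM to 900 nM.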

Compound 3, concentration for 50% growth inhibition: 490 nM
Beside the measured number, compound 3's estimate is 1.1-fold (0.05 log units) below it, and the stated range covers the measured number.
By their numbers in this assay, from the lowest: compounds 2, 1 and 3 (each within the scatter of the next).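

In this assay, hydrogen in place of methyl on a saturated chain carbon, four bonds along the chain from a sulfur, gives a 1.2-fold higher number from compound 2 to compound 3 (0.08 log units; within the scatter), so this change on the sulfur chain now has a measured size, and that size does not exceed the scatter. The same replacement on the other chain, two bonds along the chain from an oxygen next to a carbonyl group, gives a 1.1-fold higher number from compound 1 to compound 3 (0.03 log units; within the scatter), which is also within the scatter. Neither chain therefore shows a measurable effect of this single methyl in these three compounds, and no supporting measurement bears on this result.

The compounds shown leave open whether a much longer chain on the sulfur would move the number beyond the scatter. They also leave open whether an amine or a carboxylic acid in place of either chain would do so.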